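The source may hold more compounds than are shown below. What is called first, only, known or untested is meant among the compounds shown, and "the series" means these compounds.

Measured compounds:
- compound 1, `Nc1cc(N)c2nc(-c3ccccc3)c(Oc3ccc(Cl)c(Cl)c3)nc2c1`, in a functional assay on A549 cells (Homo sapiens) for inhibition, read by sulforhodamine B assay, with a stated time of 48 h; a higher number here means a weaker inhibitor of growth, a lower number a stronger inhibitor of growth: 43700 nM
- compound 2, `CCOC(=O)[C@H](CCC(=O)O)NC(=O)c1ccc(CNc2nc3cc(N)cc(N)c3nc2-c2ccccc2)cc1`, in this assay: a limit, < 100000 nM
- compound 3, `Nc1cc(N)c2nc(-c3ccccc3)c(NCc3ccc(Cl)c(Cl)c3)nc2c1`, in this assay: 27500 nM

Compound 3 carries the smaller of the two numbers recorded in this assay, but its gap to compound 1 lies within the usual scatter, so the two cannot be told apart on these data. Compound 2 is known only as a limit of the assay, (the limit of < 100000 nM in this assay, at which 1 of the 3 values shown sits), and gives no number to set beside them. Within the data shown here, no pair among the measured compounds differs in a single place, so no measured step is available to guide the next change.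

Compound 4, `COc1ccc(CNc2nc3cc(N)cc(N)c3nc2-c2ccccc2)cc1OC`, has not yet been measured in this assay. It differs from compound 3 in one place: 3,4-dimethoxyphenyl in place of 3,4-dichlorophenyl on a saturated chain carbon bound to a nitrogen on an aromatic ring. Among the measured compounds shown here, with no measured step of this kind among the compounds in hand, the change is expected to move the number little, if at all, beyond the scatter, with a slight lean toward a higher number. Compound 4 is therefore estimated at 40000 nM in this assay, within a range of 12000 nM to 100000 nM. That estimate means a step from compound 3 to compound 4 of a 1.5-fold higher number from compound 3 to compound 4 (0.16 log units; within the scatter).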

Compound 4, concentration for total growth inhibition: 50100 nM
Compound 4: middle estimate off by 1.3-fold (0.10 log units), on the low side; low and high end bracket the measured number.
By their numbers in this assay, from the lowest: compounds 3, 1 and 4 (each within the scatter of the next).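

In this assay, 3,4-dimethoxyphenyl in place of 3,4-dichlorophenyl on a saturated chain carbon bound to a nitrogen on an aromatic ring gives the first step among these compounds that differs in one place, a 1.8-fold higher number from compound 3 to compound 4 (0.26 log units; within the scatter), and this step lies within the scatter. At this position, then, a change to a larger group that carries hydrogen-bond acceptors, where the group it replaces has none, does not separate compound 3 from compound 4 on these data. Nothing measured here gives a reason for this result.

As far as these compounds go, a single step cannot show whether any group at this position would move the number beyond the scatter, and how an amine or a carboxylic acid on that phenyl ring, or a longer chain in place of the saturated chain carbon, would read in this assay remains open. Compound 2, which differs from the others in more than one place, is known only as a limit of the assay, < 100000 nM, and so adds no number to this question.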